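A few compounds are considered here, and "the series" means these few. Any claim that something is new, unique, unknown or untested is made for them only; others in the source may bear on it.

Compound 1 `CNC(=O)CCCCCCCn1nc(-c2cnc3[nH]ccc3c2)c2c(N)ncnc21`: 17400 nM
Compound 2 `Nc1ncnc2c1c(-c1cnc3[nH]ccc3c1)nn2CCCCCC(=O)NO`: "not determined" (no result reported)
Compound 3 `Nc1nc2cc(-c3nn(CCCCCC(=O)NO)c4ncnc(N)c34)ccc2o1`: 2030 nM

In a functional assay on Bel-7402 cells (Homo sapiens) for inhibition, read by MTT assay, with a stated time of 72 h (on this read-out lower numbers stand for stronger inhibition and higher numbers for weaker inhibition), compound 3 gives 2030 nM, the lower of the two numbers available and beyond the scatter from compound 1. Compound 2 has no number to compare. Compound 4 `CNC(=O)CCCCCCCn1nc(-c2ccc3oc(N)nc3c2)c2c(N)ncnc21` differs from compound 3 as follows: 2-(methylcarbamoyl)ethyl in place of hydroxycarbamoyl on a saturated chain carbon, five bonds along the chain from an aromatic nitrogen. Thus 2-(methylcarbamoyl)ethyl stands in place of hydroxycarbamoyl on a saturated chain carbon, five bonds along the chain from an aromatic nitrogen. Going by the values given here, no measured step isolates this change. However, compound 1, at 17400 nM, carries the same methylcarbamoyl-ended chain as compound 4, so a higher number, beyond the scatter, is expected. The expected change is a 6.9-fold higher number from compound 3 to compound 4 (0.84 log units; beyond the scatter). The estimate for compound 4 is 14000 nM, with an expected range from 5000 nM to 40000 nM.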

Compound 4, half-maximal inhibitory concentration: 13200 nM
Estimate against measurement, compound 4: 1.1-fold (0.03 log units) above, and the stated range covers the measured number.
By their numbers in this assay, from the lowest: compound 3; then compounds 4 and 1 (each within the scatter of the next).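

In this assay the exchange of hydroxycarbamoyl for 2-(methylcarbamoyl)ethyl on a saturated chain carbon now stands as a measured step with the aromatic group held constant, a 6.5-fold higher number from compound 3 to compound 4 (0.81 log units; beyond the scatter), beyond the scatter. With the methylcarbamoyl-ended chain kept, the change of aromatic group gives a 1.3-fold lower number from compound 1 to compound 4 (0.12 log units; within the scatter), within the scatter, so the two groups are not told apart on that chain. No measurement at hand explains either result. As far as these compounds go, compound 2 has no number, so whether hydroxycarbamoyl gives a similar step with the aromatic group of compound 1 stays open. From the compounds shown here alone, how a carboxylic acid would read in place of hydroxycarbamoyl also remains open.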